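The compounds below may be only part of what the source reports. "The series", "measured", "known", "first", "only" and "open" are said of these compounds alone.

Compound 1 `Nc1n[nH]c2cccc(-c3cccc(NC(=O)Nc4ccc(Cl)cc4Cl)c3)c12` sits at the edge of what a functional assay on A549 cells (Homo sapiens) for inhibition, read by MTT assay, with a stated time of 48 h (a lower number here means a stronger inhibitor, a higher number a weaker inhibitor), can report: its value of > 500000 nM is a limit of the assay rather than a measured number, so nothing more is known of where it stands than the limit of > 500000 nM in this assay, at which 1 of the 2 values shown sits. Its companion, compound 2 `Nc1n[nH]c2cccc(-c3cccc(NC(=O)Nc4ccc(Cl)c(C(F)(F)F)c4)c3)c12`, carries a 4-chloro-3-(trifluoromethyl)phenyl on the urea and gives 3410 nM in this assay. Among the measured compounds shown here, the two share the same core, and only the aryl group on the outer urea nitrogen differs; since no step between them is given, they show only that one compound reports a number and the other a limit.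

Compound 3 `Cc1ccc(NC(=O)Nc2cccc(-c3cccc4[nH]nc(N)c34)c2)cc1` has not yet been measured in this assay. It differs from compound 1 in one place (4-methylphenyl in place of 2,4-dichlorophenyl on an amide-type nitrogen).

For the measured compounds named here, with no measured step on which to rest, the size of the step from compound 1 to compound 3 is uncertain; a shift toward a stronger inhibitor is expected, with a real chance that compound 3 also ends at the limit. Compound 3 is estimated at 150000 nM, with a range from 10000 nM to 500000 nM, and its expected step is an at least 3.3-fold lower number from compound 1 to compound 3 (0.52 log units; beyond the scatter).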

Compound 3, half-maximal inhibitory concentration: 1660 nM
For compound 3 the middle estimate is 90-fold (1.96 log units) above the measured one; the whole stated range lies above it.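

At the amide-type nitrogen, in this assay, 4-methylphenyl in place of 2,4-dichlorophenyl gives an at least 300-fold lower number from compound 1 to compound 3 (2.47 log units; beyond the scatter), so this single change of aryl group carries the series from a limit to a measured number. Compound 1 stands only at a limit, which makes this step a minimum and leaves its full size unknown: the limit of > 500000 nM in this assay, at which 1 of the 3 values shown sits.
Compound 3 also shows that a value can be read here with a methyl-bearing ring that has no chlorine or trifluoromethyl, and the printed values of compound 3, 1660 nM, and of compound 2, 3410 nM, show that two quite different aryl groups both report a number.

The change removes two chlorines and adds a methyl at once, so the compounds shown cannot say how much each chlorine or the methyl contributes, and simpler neighbours such as phenyl, 4-chlorophenyl or 2-chlorophenyl would separate these parts. Going by these compounds, how this position responds to other groups on the ring, such as a methoxy group, an amine or a carboxylic acid, also remains open.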